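Amide side chain: from compound 3 to compound 4

This account rests on a few compounds, and the source may have more. Where it says the series, first, only, none or still open, it means among the compounds named here.

In a physicochemical assay for solubility, read by HPLC, at pH 7.4 (on this read-out lower numbers stand for lower solubility and higher numbers for higher solubility), compound 1 `CCn1c(C(=O)NCCN)ccc1C(CC)(CC)c1ccc(OCS(=O)(=O)c2ccccc2)c(C)c1` gives 65 ug/mL, compound 2 `CCN(CC)CCNC(=O)c1ccc(C(CC)(CC)c2ccc(OCS(=O)(=O)c3ccccc3)c(C)c2)n1CC` gives 117 ug/mL and compound 3 `CCn1c(C(=O)N[C@@H](C)CO)ccc1C(CC)(CC)c1ccc(OCS(=O)(=O)c2ccccc2)c(C)c1` gives 35.7 ug/mL. The step of a 1.8-fold higher number from compound 1 to compound 2 (0.26 log units; within the scatter) does not separate the first two. Compound 3 stands level with compound 1 within the scatter, with a 1.8-fold lower number from compound 1 to compound 3 (0.26 log units; within the scatter), and under compound 2, with a 3.3-fold lower number from compound 2 to compound 3 (0.52 log units; beyond the scatter).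

Compound 4 `CCn1c(C(=O)N[C@H](CO)C(C)C)ccc1C(CC)(CC)c1ccc(OCS(=O)(=O)c2ccccc2)c(C)c1` keeps the shared core and differs from compound 3 by isopropyl in place of methyl on a saturated chain carbon bound to an amide-type nitrogen and a saturated chain carbon.

Among the compounds with values here, no measured pair isolates this change. The nearest evidence is the pair of steps into compound 3, which replace the whole group on the amide-type nitrogen: one, a 1.8-fold lower number from compound 1 to compound 3 (0.26 log units; within the scatter), stays within the scatter, and the other, a 3.3-fold lower number from compound 2 to compound 3 (0.52 log units; beyond the scatter), is modest. Neither gives a direct size for the present change, but together they argue against expecting a large move in this assay.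

The expected change is small and its direction tentative, with an estimated 1.6-fold lower number from compound 3 to compound 4 (0.21 log units; within the scatter). The estimate for compound 4 is 22 ug/mL, with an expected range from 9 ug/mL to 50 ug/mL.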

Compound 4, solubility: 27.8 ug/mL
Estimate against measurement, compound 4: 1.3-fold (0.10 log units) below, and the stated range covers the measured number.
By their numbers in this assay, from the lowest: compounds 4, 3, 1 and 2 (each within the scatter of the next, the first and the last beyond it).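

a 1.3-fold lower number from compound 3 to compound 4 (0.11 log units; within the scatter) gives the first direct reading in this assay of isopropyl in place of methyl on a saturated chain carbon bound to an amide-type nitrogen and a saturated chain carbon, and compound 3 and compound 4 are not separated by it. The larger group does, however, shift the comparison with the amine-bearing side chains: a 1.8-fold lower number from compound 1 to compound 3 (0.26 log units; within the scatter) did not separate that pair, whereas a 2.3-fold lower number from compound 1 to compound 4 (0.37 log units; beyond the scatter) does, and the gap to the diethylamino compound stays beyond the scatter at a 4.2-fold lower number from compound 2 to compound 4 (0.62 log units; beyond the scatter) in this assay. Both steps are modest, and no accompanying measurement accounts for any of these steps.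

The compounds shown leave open whether a larger group at the same place, such as tert-butyl or phenyl, would move the number beyond the scatter from compound 3. They also leave open how a carboxylic acid, or a longer chain ending in hydroxyl or amine, on the amide-type nitrogen would compare with the 2-aminoethyl and 2-(diethylamino)ethyl groups.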